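This account rests on a few compounds, and the source may have more. Where it says the series, first, only, none or still open, it means among the compounds named here.

In an ADME assay on MDCK cells (Canis lupus familiaris) for permeability (a lower number here means that the compound crosses the layer more slowly, a higher number that the compound crosses the layer faster), the measured compounds are:
- compound 1 `CCS(=O)(=O)Nc1ccc(Oc2ccc(C(F)(F)F)cc2)c(-c2cn(C)c(=O)c3[nH]ccc23)c1`: 11 10^-6 cm/s
- compound 2 `Cn1cc(-c2cc(NS(C)(=O)=O)ccc2Oc2ccc(F)cc2F)c2cc[nH]c2c1=O`: 17 10^-6 cm/s

Compound 1 stands level with compound 2 on these numbers: compound 1 gives 11 10^-6 cm/s and compound 2 gives 17 10^-6 cm/s, which lie within the scatter of each other. Among the measured compounds shown here, with only two values and no measured pair that differs in one place, the data offer no step to use as a guide.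

Compound 3 `CCS(=O)(=O)Nc1ccc(OC2CCN(C)CC2)c(-c2cn(C)c(=O)c3[nH]ccc23)c1` keeps the core of compound 1 and changes one group: 1-methylpiperidin-4-yl in place of 4-(trifluoromethyl)phenyl on an oxygen on an aromatic ring. On an oxygen on an aromatic ring, a six-membered aromatic ring of carbon only gives way to a six-membered non-aromatic ring with a hetero atom. For the measured compounds named here, no measured compound carries the entering group, so the expectation rests on the structural change alone and remains uncertain. A moderate fall in this assay, beyond the scatter, is expected, although a result close to compound 1 is not ruled out. The expected size of the change is a 2.8-fold lower number from compound 1 to compound 3 (0.44 log units; beyond the scatter). For compound 3, the estimated value is 4 10^-6 cm/s, with an expected range from 1.5 10^-6 cm/s to 10 10^-6 cm/s.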

Compound 3, apparent permeability: 0.55 10^-6 cm/s
Compound 3: middle estimate off by 7.3-fold (0.86 log units), on the high side; the whole stated range lies above it.
By their numbers in this assay, from the lowest: compound 3; then compounds 1 and 2 (each within the scatter of the next).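

The group on an oxygen on an aromatic ring turns out to matter a great deal in this assay: with 1-methylpiperidin-4-yl in place of 4-(trifluoromethyl)phenyl, the step is a 20-fold lower number from compound 1 to compound 3 (1.30 log units; beyond the scatter) and counts as large. Among the compounds shown here, this is the first step in the set that changes one place only, so it is the first direct sign that this single group can move the read-out well beyond the scatter while the rest of the molecule stays the same. Nothing shown here explains the fall, so the step stands as an observation without a known cause.

The step swaps several features at once: an aromatic carbon ring gives way to a non-aromatic ring, the three fluorine atoms leave, and a ring nitrogen enters, so the compounds shown cannot say which of these changes carries the effect. Going by these compounds, a cyclohexyl group, a tetrahydropyran-4-yl group or a plain phenyl group on the same oxygen would help pull these features apart, and it remains open how any of them would behave.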